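Replacing 4-carbamoylcyclohexyl with hydrogen in compound 3

This account rests on a few compounds, and the source may have more. Where it says the series, first, only, none or still open, it means among the compounds named here.

In a physicochemical assay for lipophilicity, using the shake flask method, at pH 7.4 (on this read-out higher numbers stand for higher lipophilicity and lower numbers for lower lipophilicity), compound 3 (`CN(C)[C@H]1CC[C@H](Nc2ncnn3ccc([C@H]4CC[C@H](C(N)=O)CC4)c23)CC1`) gives 0.2 and shares the low end of the three numbers with compound 1 (`CN(C)[C@H]1CC[C@H](Nc2ncnn3ccc([C@H]4CC[C@@H](C(N)=O)CC4)c23)CC1`), which gives 0.1 on the same scale. This pair shows the fact that compounds 1 and 3 differ only in the configuration as drawn and their gap is small, a number 0.10 log units higher from compound 1 to compound 3 (within the scatter) in all. Compound 2 (`CC(C)c1ccn2ncnc(N[C@H]3CC[C@H](N(C)C)CC3)c12`) reaches 1.3 and stands clear of both, with a number 1.20 log units higher from compound 1 to compound 2 (beyond the scatter) on one side and a number 1.10 log units lower from compound 2 to compound 3 (beyond the scatter) on the other.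

Compound 4 (`CN(C)[C@H]1CC[C@H](Nc2ncnn3cccc23)CC1`) departs from compound 3 by one change (hydrogen in place of 4-carbamoylcyclohexyl on an aromatic carbon), in words hydrogen in place of 4-carbamoylcyclohexyl on an aromatic carbon. Among the measured compounds shown here, no measured step puts hydrogen at this place. The nearest guide is the exchange of isopropyl for 4-carbamoylcyclohexyl at that carbon, seen in compound 2 as a number 1.10 log units lower from compound 2 to compound 3 (beyond the scatter) and read here as a sign that the number can move a long way with this substituent. Isopropyl and hydrogen are different substituents, so only part of that large step is expected to return, upward, and it may not clear the scatter. The expected step is a number 0.20 log units higher from compound 3 to compound 4 (within the scatter) and remains an estimate. For compound 4 the estimated value is 0.4 on this assay with an expected range from 0 to 0.9 in repeated measurement.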

Compound 4, distribution coefficient: 0
Estimate against measurement, compound 4: 0.40 log units above, and the stated range covers the measured number.
By their numbers in this assay, from the lowest: compounds 4, 1 and 3 (each within the scatter of the next); then compound 2.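

In this assay, hydrogen on this aromatic carbon, two ring bonds from the ring nitrogen, cannot be told apart from 4-carbamoylcyclohexyl, with a number 0.20 log units lower from compound 3 to compound 4 (within the scatter) and a number 0.10 log units lower from compound 1 to compound 4 (within the scatter), even though the whole group and its two defined stereocentres leave. Isopropyl is the substituent that stands apart, with a number 1.30 log units lower from compound 2 to compound 4 (beyond the scatter), so the large gap seen earlier need not be read as a drop brought by 4-carbamoylcyclohexyl: measured from hydrogen, the step beyond the scatter belongs to isopropyl, while 4-carbamoylcyclohexyl gives none. The reading holds for both compounds that carry the larger group, and hydrogen removes the one feature that separates them: the fact that compounds 1 and 3 differ only in the configuration as drawn.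

The compounds shown leave open whether the number climbs steadily along a series of simple alkyl groups, such as methyl, ethyl and a plain unsubstituted cyclohexyl, or whether isopropyl is a special case. They also leave open what would happen on this cyclohexyl ring if a carboxylic acid or a primary amine took the place of the carbamoyl group.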